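Swapping a Chain End on Two Related Cores

A few compounds are considered here, and "the series" means these few. Any claim that something is new, unique, unknown or untested is made for them only; others in the source may bear on it.

Of the compounds shown here, three have been measured in a functional assay on SNU-423 cells (Homo sapiens) for inhibition, read by MTT assay, with a stated time of 72 h; on this read-out higher numbers stand for weaker inhibition and lower numbers for stronger inhibition. Compound 2, `Nc1ncnc2c1c(-c1cnc3[nH]ccc3c1)nn2CCCCCCCCC(=O)NO`, gives 7500 nM. Compound 1, `CNC(=O)CCCCCCCn1nc(-c2cnc3[nH]ccc3c2)c2c(N)ncnc21`, shares the core of compound 2 and differs only at the end of its chain: methylcarbamoyl in place of (hydroxycarbamoyl)methyl on a saturated chain carbon, seven bonds along the chain from an aromatic nitrogen. In this assay compound 1 gives 5400 nM, which is a 1.4-fold lower number from compound 2 to compound 1 (0.14 log units; within the scatter). Compound 3, `Nc1nc2cc(-c3nn(CCCCCCCCC(=O)NO)c4ncnc(N)c34)ccc2o1`, keeps the chain end of compound 2 but carries a different core; the difference between the two cores is a group of 10 heavy atoms (7 carbon, 2 nitrogen, 1 oxygen; one five-membered aromatic ring with 2 hetero atoms, one six-membered aromatic ring of carbon only) in place of a group of 9 heavy atoms (7 carbon, 2 nitrogen; one five-membered aromatic ring with 1 hetero atom, one six-membered aromatic ring with 1 hetero atom), on an aromatic carbon. In this assay compound 3 gives 4940 nM, a step of a 1.5-fold lower number from compound 2 to compound 3 (0.18 log units; within the scatter). All three numbers therefore sit close together, and none of them can be called apart from the others.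

Compound 4, `CNC(=O)CCCCCCCn1nc(-c2ccc3oc(N)nc3c2)c2c(N)ncnc21`, has not yet been measured. It combines the core of compound 3 with the chain end of compound 1: methylcarbamoyl in place of (hydroxycarbamoyl)methyl on a saturated chain carbon, seven bonds along the chain from an aromatic nitrogen. Among the compounds with values here, this is the same change that was made from compound 2 to compound 1, at the same place on the chain, so that earlier step is the only guide available. Compound 4 is expected to show a step of a 1.4-fold lower number from compound 3 to compound 4 (0.14 log units; within the scatter) in this assay, with an estimated value of 3600 nM and a likely range from 1500 nM to 9000 nM. That expectation rests on the earlier pair, because a 1.4-fold lower number from compound 2 to compound 1 (0.14 log units; within the scatter) stayed within the scatter, and a similarly small shift is assumed here.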

Compound 4, half-maximal inhibitory concentration: 280 nM
Estimate against measurement, compound 4: 13-fold (1.11 log units) above; measured number below the stated range.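

Replacing (hydroxycarbamoyl)methyl with methylcarbamoyl on the core of compound 3 gives, in this assay, an 18-fold lower number from compound 3 to compound 4 (1.25 log units; beyond the scatter), so the size of this step does not carry over from one core to the other: the same change on two cores in this assay, a 1.4-fold lower number (0.14 log units; within the scatter) from compound 2 to compound 1 and an 18-fold lower number (1.25 log units; beyond the scatter) from compound 3 to compound 4, 13-fold (1.10 log units) apart, beyond the scatter of two such steps

Seen from the other side, the change of core gives a 19-fold lower number from compound 1 to compound 4 (1.29 log units; beyond the scatter), and its size likewise depends on which chain end is present: the same change on two cores in this assay, a 1.5-fold lower number (0.18 log units; within the scatter) from compound 2 to compound 3 and a 19-fold lower number (1.29 log units; beyond the scatter) from compound 1 to compound 4, 13-fold (1.10 log units) apart, beyond the scatter of two such steps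

These two comparisons are one finding viewed in two ways: in these four compounds, the chain end and the core do not act independently, and the large drop appears only when the core of compound 3 is paired with the methylcarbamoyl end, but this does not show why, nor whether the same would happen on any other core.

The compounds shown leave open whether this result needs the methylcarbamoyl end specifically, or would also appear on the core of compound 4 with a primary amide, a carboxylic acid, an amine, or a shorter or longer chain. They also leave open whether compound 4 would stand out in the same way in cell lines other than this one.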